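The source may hold more compounds than are shown below. What is called first, only, known or untested is meant among the compounds shown, and "the series" means these compounds.

Measured so far in a functional assay on A549 cells (Homo sapiens), read by MTT assay, with a stated time of 72 h; on this read-out higher numbers stand for weaker inhibition and lower numbers for stronger inhibition:
compound 1, `COc1ncnc2c1c(-c1ccoc1)cn2[C@@H]1O[C@H](CO)[C@@H](O)[C@H]1O`: 1160 nM
compound 2, `COc1ncnc2c1c(-c1cccs1)cn2[C@@H]1O[C@H](CO)[C@@H](O)[C@H]1O`: 4850 nM
compound 3, `CSc1ncnc2c1c(-c1ccoc1)cn2[C@@H]1O[C@H](CO)[C@@H](O)[C@H]1O`: 280 nM

Compound 4, `CSc1ncnc2c1c(-c1cccs1)cn2[C@@H]1O[C@H](CO)[C@@H](O)[C@H]1O`, has not yet been measured in this assay. The core of compound 3 differs from the core of compound 1 by methylsulfanyl in place of methoxy on an aromatic carbon; this change gave a 4.1-fold lower number from compound 1 to compound 3 (0.62 log units; beyond the scatter). Compound 3 holds the lowest of the three numbers, with compound 1 nearest and compound 2 furthest, both steps beyond the scatter.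

The change from compound 3 to compound 4 is thiophen-2-yl in place of furan-3-yl on an aromatic carbon. The same change was made from compound 1 to compound 2, (thiophen-2-yl in place of furan-3-yl on an aromatic carbon), where it gave a 4.2-fold higher number from compound 1 to compound 2 (0.62 log units; beyond the scatter). The two place descriptions read the same word for word, so this is the same change, made once on each core; it occurs twice among the compounds shown.

Among the measured compounds shown here, for compound 4 the expected step is a 4.3-fold higher number from compound 3 to compound 4 (0.63 log units; beyond the scatter), matching the earlier one; this rests on a 4.2-fold higher number from compound 1 to compound 2 (0.62 log units; beyond the scatter) as the only measured instance of the change. Compound 4 is accordingly estimated at 1200 nM, expected to fall between 500 nM and 3000 nM.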

Compound 4, half-maximal inhibitory concentration: > 20000 nM
Compound 4 gave a limit, no number (the forecaster's own chance of this, stated with the estimate: 5%); middle value at least 16-fold (1.22 log units) from the limit.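

In this assay compound 4 gives > 20000 nM, which is a limit of the assay and not a number. Thiophen-2-yl in place of furan-3-yl gives an at least 71-fold higher number from compound 3 to compound 4 (1.85 log units; beyond the scatter), so the direction of the change carries over from the methoxy core to the methylsulfanyl core, but its size does not: the same change on two cores in this assay, a 4.2-fold higher number (0.62 log units; beyond the scatter) from compound 1 to compound 2 and an at least 71-fold higher number (1.85 log units; beyond the scatter) from compound 3 to compound 4, at least 17-fold (1.23 log units) apart, beyond the scatter of two such steps Methylsulfanyl in place of methoxy gives an at least 4.1-fold higher number from compound 2 to compound 4 (0.61 log units; beyond the scatter), the opposite direction to its step with furan-3-yl, so the two changes do not act independently in these four compounds, although the limit leaves the full size of both new steps unknown and the data do not show the reason for the mismatch: the same change on two cores in this assay, a 4.1-fold lower number (0.62 log units; beyond the scatter) from compound 1 to compound 3 and an at least 4.1-fold higher number (0.61 log units; beyond the scatter) from compound 2 to compound 4, at least 17-fold (1.23 log units) apart, beyond the scatter of two such steps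

The compounds shown leave open whether this dependence on the partner group extends beyond furan-3-yl and thiophen-2-yl, for instance to furan-2-yl, thiophen-3-yl or phenyl on the same aromatic carbon. From the compounds shown here alone, it is also open how an amine or a longer alkylsulfanyl chain in place of methylsulfanyl would behave with each of these rings.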